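This account rests on a few compounds, and the source may have more. Where it says the series, first, only, none or still open, it means among the compounds named here.

Measured so far:
compound 1, `C=CCN(C)c1nc(N)nc2c1ncn2[C@H]1C[C@H](N=[N+]=[N-])[C@@H](CO)O1`: 27000 nM
compound 2, `COc1nc(N)c2ncn([C@H]3C[C@H](N=[N+]=[N-])[C@@H](CO)O3)c2n1`: > 100000 nM

In an ADME assay on CCRF-CEM cells (Homo sapiens) for cytotoxicity, with a stated time of 5 days (a lower number here means a stronger inhibitor, a higher number a weaker inhibitor), compound 1 gives 27000 nM. For compound 2 the result in this assay is a limit of the assay rather than a number, > 100000 nM. For the measured compounds named here, compound 1 therefore stands as the only numerical value in this small set, the other entry being (the limit of > 100000 nM in this assay, at which 1 of the 2 values shown sits). The unmeasured compound 3, `C=CCNc1nc(N)nc2c1ncn2[C@H]1C[C@H](N=[N+]=[N-])[C@@H](CO)O1`, differs from compound 1 by hydrogen in place of methyl on a nitrogen on an aromatic ring. No pair of measured compounds differs in a single place, so the size of such a step cannot be read from the data shown. The change is expected to be modest, an estimated 1.1-fold higher number from compound 1 to compound 3 (0.05 log units; within the scatter) in this assay, which would lie within the usual scatter of repeated measurements. Compound 3 is accordingly estimated at 30000 nM in this assay, with a range from 8000 nM to 100000 nM.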

Compound 3, half-maximal inhibitory concentration: > 100000 nM
Compound 3: only a limit was reported (the forecaster's own chance of this, stated with the estimate: 25%); at least 3.3-fold (0.52 log units) between middle value and limit.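

In this assay compound 3 gives > 100000 nM, which is a limit of the assay and not a number. For the compounds shown here, the change from allyl(methyl)amino to allylamino gives an at least 3.7-fold higher number from compound 1 to compound 3 (0.56 log units; beyond the scatter), the first single-place step in this set, so this one change does shift the read-out here. The full size of that step cannot be read because the result for compound 3 is a limit, as is most of this small set: the limit of > 100000 nM in this assay, at which 2 of the 3 values shown sit.

The compounds shown leave open whether ethyl or a longer chain in place of methyl on this nitrogen would keep the number near that of compound 1. Also open, as far as these compounds go, is what a cyclopropyl group in place of allyl would do while the methyl stays.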